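A Cyclopentylsulfanyl Analogue Tested for Cell Tolerance

A few compounds are considered here, and "the series" means these few. Any claim that something is new, unique, unknown or untested is made for them only; others in the source may bear on it.

In an ADME assay on BCBL1 cells (Homo sapiens) for cytotoxicity, with a stated time of 7 days (a lower number here means that less compound is tolerated, a higher number that more compound is tolerated), compound 2 `CCCNc1nc(N)nc2c1ncn2/C=C1/CC1(CO)CO` reaches only the limit of the measurement, > 20000 nM. Compound 1 `Nc1nc(OCC(F)(F)F)c2ncn(/C=C3/CC3(CO)CO)c2n1` also gives just a limit, > 20000 nM. The step that the two limits leave unreadable from compound 1 to compound 2 is therefore not readable; both values rest at the limit of > 20000 nM in this assay, at which 2 of the 2 values shown sit. Compound 3 `Nc1nc(SC2CCCC2)c2ncn(/C=C3/CC3(CO)CO)c2n1` differs from compound 2 by cyclopentylsulfanyl in place of propylamino on an aromatic carbon. Among the measured compounds shown here, no measured step resembles this change, so the expectation rests on where compound 2 stands. Compound 3 is expected to stay at the limit of this assay, a step of a number no higher from compound 2 to compound 3 (the limit leaves the size open). The estimated value for compound 3 is 20000 nM, between 6000 nM and 50000 nM.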

Compound 3, half-maximal cytotoxic concentration: > 20000 nM
Compound 3 gave a limit, no number; the forecaster's own chance of this, stated with the estimate: 70%; the middle value sits exactly at the limit.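

Compound 1, compound 2 and compound 3 each give a limit rather than a number, so no step between them can be read: the limit of > 20000 nM in this assay, at which 3 of the 3 values shown sit.

As far as these compounds go, whether the group exchanged on the shared core changes cell tolerance at all stays open.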